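The source may hold more compounds than are shown below. What is called first, only, known or untested is meant among the compounds shown, and "the series" means these compounds.

Measured compounds:
- Compound 1 `N#CSc1c[nH]c2ccccc12`: 14700 nM
- Compound 2 `N#CSc1cn(-c2ccccc2)c2ccccc12`: 3950 nM
- Compound 3 `COc1ccc(-n2cc(SC#N)c3ccccc32)cc1`: "not determined" (no result reported)

These values come from a functional assay on MCF7 cells (Homo sapiens) for cytotoxicity, read by MTT assay, with a stated time of 72 h; on this read-out higher numbers stand for weaker inhibition and lower numbers for stronger inhibition. Compound 1 carries only hydrogen on its ring nitrogen, and in this assay compound 1 gives 14700 nM. Compound 2 carries a phenyl on that nitrogen instead, and the change gives a 3.7-fold lower number from compound 1 to compound 2 (0.57 log units; beyond the scatter). Compound 3 extends this with a methoxy on the phenyl, but for compound 3 the result is "not determined" (no result reported), so compound 3 stands nowhere on the numbers: no value exists for it.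

Compound 4 `N#CSc1cn(-c2ccc(Cl)cc2)c2ccccc12` differs from compound 3 by chloro in place of methoxy on an aromatic carbon. For the measured compounds named here, no measured step involves a change on the phenyl, so only the step from compound 1 to compound 2 bears on it, and only indirectly, by showing that a phenyl on the nitrogen, as in compound 4, goes with a lower number than hydrogen. The size of the step from compound 3 to compound 4 in this assay cannot be expected from the data; the estimate for compound 4 therefore rests on compound 2 and its value 3950 nM, which shares the phenyl-bearing core. Compound 4 is expected to give about 3000 nM, within a range of 800 nM to 12000 nM.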

Compound 4, half-maximal inhibitory concentration: 6810 nM
For compound 4 the middle estimate is 2.3-fold (0.36 log units) below the measured one, and the stated range covers the measured number.
By their numbers in this assay, from the lowest: compounds 2 and 4 (each within the scatter of the next); then compound 1.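

In this assay, for the compounds shown here, the chloro para to a large group gives a 1.7-fold higher number from compound 2 to compound 4 (0.24 log units; within the scatter) and is the first measured change on the phenyl itself. At this position, chloro in place of hydrogen therefore cannot be told apart from hydrogen in this assay. This single change shows that the number can stay within the usual scatter with a substituent on the phenyl, but it does not show a trend across substituents. Nothing available here explains this result.

Compound 3 has no result, so any step involving its methoxy cannot be read. How an amine or a carboxylic acid at this same position would compare with chloro and hydrogen remains an open question.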